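A few compounds are considered here, and "the series" means these few. Any claim that something is new, unique, unknown or untested is made for them only; others in the source may bear on it.

Compound 1, `N#Cc1c[nH]c2ncnc(N)c12`, is followed here into compound 3, `CCCn1cc(C#N)c2c(N)ncnc21`. Among the compounds with values here, in a functional assay on KB cells (Homo sapiens) for cytotoxicity (a lower number here means a stronger inhibitor, a higher number a weaker inhibitor), compound 1 gives 18000 nM, one of only two numbers so far. The other belongs to compound 2, `NC(=S)c1c[nH]c2ncnc(N)c12`, which in this assay gives 25000 nM; the step of a 1.4-fold higher number from compound 1 to compound 2 (0.14 log units; within the scatter) lies within the scatter. Compound 3 differs from compound 1 by propyl in place of hydrogen on an aromatic nitrogen. Within the data shown here, the single measured step concerns a group on an aromatic carbon, not on an aromatic nitrogen, and it was a 1.4-fold higher number from compound 1 to compound 2 (0.14 log units; within the scatter), so it does not bear on the change to compound 3. Among the measured compounds shown here, no measured step speaks to a propyl in place of hydrogen on an aromatic nitrogen, and nothing in the data points to a step in this assay in either direction beyond the scatter. Compound 3 is therefore expected to give 18000 nM, within 5000 nM to 60000 nM, which means an expected step of no change at the digits printed from compound 1 to compound 3 (within the scatter).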

Compound 3, half-maximal inhibitory concentration: > 100000 nM
Compound 3: only a limit was reported (the forecaster's own chance of this, stated with the estimate: 15%); at least 5.5-fold (0.74 log units) between middle value and limit.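

In this assay, the aromatic nitrogen of the five-membered ring proves to be a place where a change registers: propyl in place of hydrogen gives an at least 5.5-fold higher number from compound 1 to compound 3 (0.74 log units; beyond the scatter), toward a weaker inhibitor. The only earlier step, on an aromatic carbon, was a 1.4-fold higher number from compound 1 to compound 2 (0.14 log units; within the scatter), so this is the first change beyond the scatter among the compounds shown. The figure for compound 3 is a limit and not a number: the limit of > 100000 nM in this assay, at which 1 of the 3 values shown sits.

From the compounds shown here alone, whether a shorter chain such as methyl on this nitrogen, or a propyl chain ending in an amine or a carboxylic acid, would move the number the same way stays open. Going by these compounds, it is also open whether propyl on this nitrogen would do the same in compound 2.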